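The compounds below may be only part of what the source reports. "The series", "measured", "known", "first", "only" and "open" are said of these compounds alone.

Compound 1, `COc1cc(/C=C/C(C)=O)ccc1OCc1cn(-c2ccccc2CO)nn1`, gives 50300 nM in a functional assay on PC-3 cells (Homo sapiens) for antiproliferative activity, read by MTT assay, with a stated time of 48 h; on this read-out higher numbers stand for weaker inhibition and lower numbers for stronger inhibition.
Compound 2, `COc1ccc(-n2cc(COc3ccc(/C=C/C(C)=O)cc3OC)nn2)cc1`, gives 2010 nM in this assay.
Compound 3, `COc1cccc(-n2cc(COc3ccc(/C=C/C(C)=O)cc3OC)nn2)c1`, gives 31600 nM in this assay.

Compound 3 sits second highest of the three numbers: its value and that of compound 1 lie within the scatter of each other, while compound 2 stands well apart, as a 16-fold higher number from compound 2 to compound 3 (1.20 log units; beyond the scatter) shows. The unmeasured compound 4, `COc1cc(/C=C/C(C)=O)ccc1OCc1cn(-c2ccccc2OC)nn1`, differs from compound 3 in one place: 2-methoxyphenyl in place of 3-methoxyphenyl on an aromatic nitrogen. Within the data shown here, no measured step moves a methoxy group between these two positions, so the bearing steps are indirect. The position of the methoxy group matters greatly, since a 16-fold higher number from compound 2 to compound 3 (1.20 log units; beyond the scatter) is large, and a group standing where the new methoxy will stand was weak in compound 1, as a 25-fold lower number from compound 1 to compound 2 (1.40 log units; beyond the scatter) and a 1.6-fold lower number from compound 1 to compound 3 (0.20 log units; within the scatter) show. Both companions of compound 2 are therefore weak, and nothing in the data marks the new position as favourable. Compound 4 is expected to stay near compound 3, with a 1.3-fold lower number from compound 3 to compound 4 (0.10 log units; within the scatter) and no step beyond the scatter. The estimate for compound 4 in this assay is 25000 nM, between 6000 nM and 90000 nM.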

Compound 4, half-maximal inhibitory concentration: 2050 nM
For compound 4 the middle estimate is 12-fold (1.09 log units) above the measured one, outside the stated range (below it).
By their numbers in this assay, from the lowest: compounds 2 and 4 (each within the scatter of the next); then compounds 3 and 1 (each within the scatter of the next).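

Among the three methoxy compounds, the position of the methoxy group does not act as a simple graded change in this assay: 2-methoxyphenyl in place of 3-methoxyphenyl gives a 15-fold lower number from compound 3 to compound 4 (1.19 log units; beyond the scatter), while 2-methoxyphenyl in place of 4-methoxyphenyl gives only a 1.0-fold higher number from compound 2 to compound 4 (0.01 log units; within the scatter), which leaves the 2-methoxyphenyl and 4-methoxyphenyl compounds level and the 3-methoxyphenyl compound apart from both. The same aromatic carbon was seen before only with hydroxymethyl on it, and that compound gave a high number, but methoxy in place of hydroxymethyl there gives a 25-fold lower number from compound 1 to compound 4 (1.39 log units; beyond the scatter), so this carbon can carry a group in a compound with a low number, and the identity of the group on it counts. Nothing measured here accounts for either large step or for the match between the two low numbers.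

The compounds shown leave open whether the low number at this carbon belongs to methoxy itself or would also hold for an ethoxy chain, a chlorine atom or a carboxylic acid there. They also leave open how a plain phenyl, with no group on it, compares with these methoxyphenyl compounds.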